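Ring-nitrogen substituent change: compound 2 to compound 4

This account rests on a few compounds, and the source may have more. Where it says the series, first, only, none or still open, it means among the compounds named here.

Measured compounds:
Compound 1 `NC(=O)c1c(NC(=O)c2ccccc2Cl)sc2c1CCN(Cc1ccccc1)C2`: 12000 nM
Compound 2 `Cc1ccccc1CN1CCc2c(sc(NC(=O)c3ccccc3Cl)c2C(N)=O)C1`: > 50000 nM (a limit of the assay, not a number)
Compound 3 `NC(=O)c1c(NC(=O)c2ccccc2F)sc2c1CCN(Cc1cccc(Cl)c1)C2`: 19800 nM

In a functional assay on HL-60 cells (Homo sapiens) for antiproliferative activity, with a stated time of 24 h (on this read-out higher numbers stand for weaker inhibition and lower numbers for stronger inhibition), compound 1 gives 12000 nM and compound 3 gives 19800 nM. For compound 2 this assay reports only the limit > 50000 nM, so compound 2 stands at the weak end of the shown numbers without a value of its own. Going by the values given here, the one measured single-point step is an at least 4.1-fold higher number from compound 1 to compound 2 (0.61 log units; beyond the scatter), which sits at the limit of > 50000 nM in this assay, at which 1 of the 3 values shown sits.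

Compound 4 `Cc1ccccc1NC(=S)N1CCc2c(sc(NC(=O)c3ccccc3Cl)c2C(N)=O)C1` is not yet measured. It differs from compound 2 by a group of 10 heavy atoms (8 carbon, 1 nitrogen, 1 sulfur; one six-membered aromatic ring of carbon only) in place of a group of 8 heavy atoms (8 carbon; one six-membered aromatic ring of carbon only), on an amine nitrogen in a ring. Among the compounds with values here, no measured step changes this group on the amine nitrogen in a ring; the step from compound 1 to compound 2 only adds a methyl on the 2-methylbenzyl and gives no guide to removing that group entirely. Compound 1 and compound 3 show that the series can reach numbers below the limit when the ring nitrogen carries a benzyl-type group.

Within the data shown here, with no step that bears on this exchange, the expected step is an at least 1.6-fold lower number from compound 2 to compound 4 (0.22 log units; that floor lies within the scatter), taken as uncertain in direction. The estimate for compound 4 in this assay is 30000 nM, with a range from 8000 nM to 120000 nM.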

Compound 4, half-maximal inhibitory concentration: 22600 nM
Compound 4: middle estimate off by 1.3-fold (0.12 log units), on the high side; the range from low to high includes it.
By their numbers in this assay, from the lowest: compounds 1, 3 and 4 (each within the scatter of the next). At a limit, above all of these: compound 2.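

In this assay, going by these compounds alone, the amine nitrogen in a ring now shows its first exchange of the whole substituent, and the 2-methylbenzyl is not the only group that can be compared there: an at least 2.2-fold lower number from compound 2 to compound 4 (0.34 log units; beyond the scatter). The reading for compound 2 is a limit and not a number, so this step gives only a bound on the size of the change: the limit of > 50000 nM in this assay, at which 1 of the 4 values shown sits. Compound 4 keeps a methyl on its aromatic ring yet returns a number rather than a limit, and the comparison with the unmethylated benzyl of compound 1 gives a 1.9-fold higher number from compound 1 to compound 4 (0.27 log units; within the scatter), so a group of this larger kind can be placed on this nitrogen without separating from compound 1 in this read-out.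

The compounds shown do not separate the contributions of the sulfur, the added nitrogen and the methyl within the group entering in compound 4. Also open, as far as these compounds go, is how a urea carbonyl in place of the sulfur, or a longer chain carrying the aromatic ring on the same nitrogen, would read in this assay.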